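Aryl Amine in Place of Piperidine: Compound 4 Expected

This account rests on a few compounds, and the source may have more. Where it says the series, first, only, none or still open, it means among the compounds named here.

Of the compounds shown here, three sharing one core have been measured in a functional assay on HCT-116 cells (Homo sapiens) for antiproliferative activity, read by CCK-8 assay, with a stated time of 72 h, tested at 8 uM; a lower number here means a weaker effect, a higher number a stronger effect of the compound at the concentration tested. Compound 1 `Cc1ccc(Nc2nc(Cl)nc3c2ncn3Cc2ccc(C(=O)Nc3ccccc3N)cc2)cc1` gives 81.5% in this assay. Compound 2 `Nc1ccccc1NC(=O)c1ccc(Cn2cnc3c(NCc4ccccc4)nc(Cl)nc32)cc1` gives 78.4% in this assay, and compound 3 `CC1CCN(c2nc(Cl)nc3c2ncn3Cc2ccc(C(=O)Nc3ccccc3N)cc2)CC1` gives 78.6% in this assay. Among these three numbers compound 3 stands second highest, with compound 2 nearest and compound 1 furthest, but both gaps lie within the scatter, so the three compounds cannot be ordered by this assay. The step of a number 2.9 percentage points lower from compound 1 to compound 3 (within the scatter) and the step of a number 0.2 percentage points higher from compound 2 to compound 3 (within the scatter) show that exchanging the group on that aromatic carbon has so far produced nothing beyond the scatter.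

Compound 4 `Nc1ccccc1NC(=O)c1ccc(Cn2cnc3c(Nc4cccc(Cl)c4)nc(Cl)nc32)cc1` differs from compound 3 in one place: (3-chlorophenyl)amino in place of 4-methylpiperidin-1-yl on an aromatic carbon. For the measured compounds named here, this is the same kind of exchange, run the other way, as the one from compound 1 to compound 3, where a ring amine took the place of an aryl amine. Since both bearing steps stayed within the scatter, no step beyond the scatter is expected in this assay. Compound 4 is expected to give 80%, in a range from 70% to 90%. The expected step is a number 1.4 percentage points higher from compound 3 to compound 4 (within the scatter), a shift that stays within the scatter.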

Compound 4, a percentage reported as inhibition, at one concentration (the size of the read-out at that concentration, not a potency): 78.4%
Compound 4: the middle estimate sits 1.6 percentage points above what was measured; low and high end bracket the measured number.
By their numbers in this assay, from the lowest: compounds 2, 4, 3 and 1 (each within the scatter of the next).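

In this assay the change from ring amine back to aryl amine, now with a chlorine on the phenyl ring, shows a number 0.2 percentage points lower from compound 3 to compound 4 (within the scatter), and the two exchanges on the nitrogen show no change at the digits printed from compound 2 to compound 4 (within the scatter) and a number 3.1 percentage points lower from compound 1 to compound 4 (within the scatter). The earlier compounds shown here had tried only a 4-methylphenyl, a benzyl and a 4-methylpiperidin-1-yl group here; the 3-chlorophenyl step adds a chlorine-bearing aromatic ring and still stays within the scatter, so the four groups on this aromatic carbon cannot be told apart in this assay, whether the entering group carries a methyl or a chloro substituent and whether the nitrogen stands in a ring or carries a hydrogen. No independent measurement is available that would account for this flat result.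

The compounds shown leave open whether a group of a different kind on this carbon, such as a morpholine, a simple primary amine or a longer chain ending in a carboxylic acid, would produce a step beyond the scatter. They also leave open whether these compounds, all read at a single concentration, would show a stronger or weaker effect at any other concentration, since the read-out gives only the size of the effect at that concentration.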